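Swapping an aminopiperidine for an ethylpiperazine on a shared core

The source may hold more compounds than are shown below. What is called first, only, known or untested is meant among the compounds shown, and "the series" means these compounds.

Of the compounds shown here, three built on one core have been tested in an ADME assay on HOS cells (Homo sapiens) for cytotoxicity; on this read-out lower numbers stand for higher toxicity in this test and higher numbers for lower toxicity in this test. Compound 1 `CC(C)CN(Cc1cn2c(N3CCN(C)CC3)cccc2n1)[C@H]1CCCc2cccnc21` gives 20000 nM. Compound 3 `CN(Cc1cn2c(N3CCC(N)CC3)cccc2n1)[C@H]1CCCc2cccnc21` gives 6300 nM. Compound 2 `CN1CCN(c2cccn3cc(CN(C)[C@H]4CCCc5cccnc54)nc23)CC1` gives only a limit of the test, > 5000 nM, rather than a number. Among the two actual numbers, compound 3 sits lowest, and compound 1 lies beyond the usual scatter above it; the limit of compound 2 cannot be placed against either.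

Compound 4 `CCN1CCN(c2cccc3nc(CN(C)[C@H]4CCCc5cccnc54)cn23)CC1` has not yet been measured in this assay. It differs from compound 3 in one place: 4-ethylpiperazin-1-yl in place of 4-aminopiperidin-1-yl on an aromatic carbon. The amine that could donate a hydrogen bond is gone, replaced by an ethyl group on the second ring nitrogen.

For the measured compounds named here, no pair of measured compounds differing in just this way exists here, so the size of the step is open. The available numbers cluster in a narrow band, and the expectation is that the change from compound 3 to compound 4 shifts the value only modestly, if at all, within the scatter: a 1.4-fold higher number from compound 3 to compound 4 (0.15 log units; within the scatter). For compound 4 the estimated result in this assay is 9000 nM, expected to fall between 3000 nM and 30000 nM, with a fair chance that the test again reports only a limit.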

Compound 4, half-maximal cytotoxic concentration: 3900 nM
Compound 4: middle estimate off by 2.3-fold (0.36 log units), on the high side; measured number inside the range.
By their numbers in this assay, from the lowest: compounds 4 and 3 (each within the scatter of the next); then compound 1.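

In this assay, placing 4-ethylpiperazin-1-yl in place of 4-aminopiperidin-1-yl on an aromatic carbon, next to the ring nitrogen, gives a 1.6-fold lower number from compound 3 to compound 4 (0.21 log units; within the scatter). This is the only direct reading of a change at this position among the compounds shown, and it means that compound 3 and compound 4 cannot be told apart in this test, even though the hydrogen-bond donor of the 4-aminopiperidin-1-yl group is absent from the 4-ethylpiperazin-1-yl group and the ring gains a second hetero atom. Compound 2, which carries methyl where compound 4 carries ethyl on the ring nitrogen, gives only a limit of the assay and not a number: the limit of > 5000 nM in this assay, at which 1 of the 4 values shown sits.

Steps that involve that limit cannot be read, so the effect of lengthening methyl to ethyl stays unknown, and nothing shown explains why the values fall where they do. Also open, from the compounds shown here alone, is whether a quite different group on this aromatic carbon, such as a carboxylic acid or an open-chain amine without a ring, would move the number beyond the usual scatter.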